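The source may hold more compounds than are shown below. What is called first, only, known or untested is meant among the compounds shown, and "the series" means these compounds.

Compound 1 `Cc1cn(C2CC(N=[N+]=[N-])C(COC(=O)NCCCO)O2)c(=O)[nH]c1=O` is read in a functional assay on MT4 cells (Homo sapiens) for cytotoxicity (on this read-out higher numbers stand for lower toxicity in this test and lower numbers for higher toxicity in this test), only as a limit: compound 1 gives > 50000 nM, a limit of this test rather than a number. Compound 2 `Cc1cn(C2CC(N=[N+]=[N-])C(COC(=O)NCCCC(=O)OC(C)(C)C)O2)c(=O)[nH]c1=O` likewise returns only a limit, > 50000 nM. Compound 3 `Cc1cn(C2CC(N=[N+]=[N-])C(COC(=O)OCCCC(=O)OC(C)(C)C)O2)c(=O)[nH]c1=O` also stops at a limit, > 50000 nM. Within the data shown here, the single one-place step measured so far, a step that the two limits leave unreadable from compound 1 to compound 2, therefore cannot be sized, since (the limit of > 50000 nM in this assay, at which 3 of the 3 values shown sit). Compound 4 `Cc1cn(C2CC(N=[N+]=[N-])C(COC(=O)CCCC(=O)O)O2)c(=O)[nH]c1=O` differs from compound 1 by 3-carboxypropyl in place of (3-hydroxypropyl)amino on a carbonyl carbon. Among the measured compounds shown here, no measured step bears readably on this change, so no direction or size of step in this assay can be drawn from the series; the expectation is that compound 4 shows no step beyond the scatter, estimated as a step that the limit leaves unreadable from compound 1 to compound 4. Compound 4 is accordingly expected at 60000 nM, with a range from 30000 nM to 150000 nM, most likely again as a limit.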

Compound 4, half-maximal cytotoxic concentration: > 50000 nM
Compound 4 gave a limit, no number; the forecaster's own chance of this, stated with the estimate: 85%; the middle value does not contradict the limit.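

No step can be read between compound 1 and compound 4, because both stop at a limit: the limit of > 50000 nM in this assay, at which 4 of the 4 values shown sit.

From the compounds shown here alone, whether 3-carboxypropyl in place of (3-hydroxypropyl)amino on a carbonyl carbon changes the read-out in this assay at all stays open.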